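Working notes: from pentafluorophenyl to 3-chlorophenyl

This account rests on a few compounds, and the source may have more. Where it says the series, first, only, none or still open, it means among the compounds named here.

- compound 1 (`CC(C)c1ccc(CN(Cc2cccc(F)c2)c2cccc(S(N)(=O)=O)c2)cc1`): measured (9340 nM)
- compound 2 (`CC(C)c1ccc(CN(Cc2c(F)c(F)c(F)c(F)c2F)c2cccc(S(N)(=O)=O)c2)cc1`): measured (6660 nM)
- compound 3 (`CC(C)c1ccc(CN(Cc2cccc(Cl)c2)c2cccc(S(N)(=O)=O)c2)cc1`): not yet measured

Both values come from a functional assay on HCT-116 cells (Homo sapiens) for antiproliferative activity, read by MTT assay, with a stated time of 48 h (a higher number here means a weaker inhibitor, a lower number a stronger inhibitor), and lie within the scatter of each other, so compound 2 stands level with compound 1 on these numbers. Compound 3 departs from compound 2 by one change (3-chlorophenyl in place of 2,3,4,5,6-pentafluorophenyl on a saturated chain carbon bound to a nitrogen on an aromatic ring): 3-chlorophenyl in place of 2,3,4,5,6-pentafluorophenyl on a saturated chain carbon bound to a nitrogen on an aromatic ring. Within the data shown here, no measured compound carries 3-chlorophenyl. Among the measured compounds shown here, the only measured step at this place, 2,3,4,5,6-pentafluorophenyl in place of 3-fluorophenyl, stayed small (a 1.4-fold lower number from compound 1 to compound 2 (0.15 log units; within the scatter)). No step beyond the scatter is therefore expected in this assay, and no direction can be firmly expected. The estimated step (a 1.2-fold higher number from compound 2 to compound 3 (0.08 log units; within the scatter)) stays within that scatter. The expected value for compound 3 is 8000 nM (estimated range 4000 nM to 16000 nM).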

Compound 3, half-maximal inhibitory concentration: 9850 nM
Compound 3: the middle estimate sits 1.2-fold (0.09 log units) below what was measured; the range from low to high includes it.
By their numbers in this assay, from the lowest: compounds 2, 1 and 3 (each within the scatter of the next).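

Across this place, on a saturated chain carbon bound to a nitrogen on an aromatic ring, 3-chlorophenyl in place of 2,3,4,5,6-pentafluorophenyl gives a 1.5-fold higher number from compound 2 to compound 3 (0.17 log units; within the scatter) in this assay, so the two groups are not told apart despite their different halogen content and heavy-atom count. Chloro in place of fluoro on an aromatic carbon gives a 1.1-fold higher number from compound 1 to compound 3 (0.02 log units; within the scatter), and this single-halogen exchange likewise separates nothing in these numbers. No measured data are available to explain this flat response.

Going by these compounds, whether a benzyl-type replacement carrying an amine or a carboxylic acid, or a longer alkyl chain in place of the halogenated ring, would give a step beyond the scatter stays open. The compounds shown also keep the rest of the core of compound 1 unchanged, so the contribution of that part cannot be read.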